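4-Ethylphenyl for 4-hydroxy-2-methylphenyl at the limit

The compounds below may be only part of what the source reports. "The series", "measured", "known", "first", "only" and "open" are said of these compounds alone.

In a functional assay on HCC 2998 cells (Homo sapiens) for inhibition, read by sulforhodamine B assay, with a stated time of 48 h (on this read-out higher numbers stand for weaker inhibition of growth and lower numbers for stronger inhibition of growth), compound 1 `Cc1ccc(C2=NN(c3ccc(S(C)(=O)=O)cc3)C(=O)CC2)cc1` gives > 100000 nM, a limit of the assay. In this assay compound 2 `Cc1cc(O)ccc1C1=NN(c2ccc(S(C)(=O)=O)cc2)C(=O)CC1` gives > 100000 nM, again only a limit, so its position is bounded and not a number; the limit of > 100000 nM in this assay, at which 2 of the 2 values shown sit, applies to both compounds. Compound 3 `CCc1ccc(C2=NN(c3ccc(S(C)(=O)=O)cc3)C(=O)CC2)cc1` carries 4-ethylphenyl in place of 4-hydroxy-2-methylphenyl on a carbon with a double bond to nitrogen. Going by the values given here, the only measured step, a step that the two limits leave unreadable from compound 1 to compound 2, has no readable size or direction. No change beyond the scatter is therefore expected, and the expected step is a number no higher from compound 2 to compound 3 (the limit leaves the size open). Compound 3 is estimated at 100000 nM, with an expected range of 50000 nM to 200000 nM.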

Compound 3, concentration for total growth inhibition: 53400 nM
For compound 3 the middle estimate is 1.9-fold (0.27 log units) above the measured one, and the stated range covers the measured number.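

Going by these compounds alone, on the carbon with a double bond to nitrogen, 4-ethylphenyl gives the first actual number of the series in this assay, where the earlier compounds gave only limits. The readable steps are an at least 1.8-fold lower number from compound 2 to compound 3 (0.27 log units; that floor lies within the scatter) and an at least 1.8-fold lower number from compound 1 to compound 3 (0.27 log units; that floor lies within the scatter), so neither change is established as going beyond the scatter. Their full sizes stay open, as both steps start from a limit: the limit of > 100000 nM in this assay, at which 2 of the 3 values shown sit.

From the compounds shown here alone, whether a longer chain such as propyl would shift the number further remains open. So does the effect of an amine or a carboxylic acid on the same phenyl ring.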